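The source may hold more compounds than are shown below. What is called first, only, known or untested is meant among the compounds shown, and "the series" means these compounds.

Going by the values given here, the series shares one core, and the three measured members are compound 1 `COc1cc(C)cc(-c2c(-c3ccnc(-c4ccc(C(C)=O)cc4)c3)cnn2CC#N)c1`, compound 2 `Cc1cc(O)cc(-c2nn(CC#N)cc2-c2ccnc(-c3ccc(Oc4ccccc4)cc3)c2)c1` and compound 3 `COc1cc(C)cc(-c2nn(CC#N)cc2-c2ccnc(-c3ccc(N(C)C)cc3)c2)c1`. In a functional assay on MOLT-4 cells (Homo sapiens) for cytotoxicity, read by sulforhodamine B assay, with a stated time of 48 h, tested at 10 uM (a higher number here means a weaker effect of the compound at the concentration tested, a lower number a stronger effect), compound 1 gives 14%. In this assay compound 2 gives -21%, and compound 3 gives 1%. Among the three numbers compound 3 stands second highest: the value nearest to it is that of compound 1, which lies higher and beyond the scatter, while the value furthest from it is that of compound 2, which lies lower and likewise beyond the scatter.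

The unmeasured compound 4 `Cc1cc(O)cc(-c2nn(CC#N)cc2-c2ccnc(-c3ccc(N(C)C)cc3)c2)c1` differs from compound 3 in a single place: hydrogen in place of methyl on an oxygen on an aromatic ring. Read one bond further out, the change is methoxy to hydroxy on the 3-methoxy-5-methylphenyl group, which becomes 3-hydroxy-5-methylphenyl.

Among the compounds with values here, no pair of measured compounds shows this change on its own, so its effect has to be guessed. Within the data shown here, the only hydroxy-bearing member, compound 2, gives the lowest value of the three, but it also carries a different substituent elsewhere. A small step downward, or none beyond the scatter, is expected, a number 6 percentage points lower from compound 3 to compound 4 (within the scatter). Compound 4 is estimated to give -5% in this assay, within a range from -25% to 15%.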

Compound 4, a percentage reported as activity, at one concentration (the size of the read-out at that concentration, not a potency): -6%
The estimate for compound 4 lay 1 percentage points above the measured number; the range from low to high includes it.
By their numbers in this assay, from the lowest: compound 2; then compounds 4 and 3 (each within the scatter of the next); then compound 1.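

Read on its own for the first time, the change from methoxy to hydroxy on the 3-methoxy-5-methylphenyl group gives a number 7 percentage points lower from compound 3 to compound 4 (within the scatter) in this assay, so at this position the methyl on the oxygen can be replaced by hydrogen without a shift that exceeds the usual scatter. Compound 4 also gives the hydroxy-bearing compound 2 a partner that differs from it in one place: dimethylamino in place of phenoxy on an aromatic carbon gives a number 15 percentage points higher from compound 2 to compound 4 (beyond the scatter), and the low number of compound 2 therefore goes with the phenoxy group in this pair, not with the hydroxy group alone. Nothing available gives a measured reason for either step.

As far as these compounds go, it remains open whether the methoxy to hydroxy change stays this small when phenoxy, or the acetyl group of compound 1, sits at the other end of the molecule, since only the dimethylamino pair shows it. From the compounds shown here alone, it is equally open how a longer ether such as ethoxy, or an amine in place of the oxygen, would read in this assay at this position.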